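The source may report more compounds than this note shows. Statements on the series, on what has been measured and on what is new or still open speak of the compounds shown alone.

In a functional assay on U-937 cells (Homo sapiens) for cytotoxicity, read by MTT assay, with a stated time of 48 h (a lower number here means a stronger inhibitor, a higher number a weaker inhibitor), compound 1 `Fc1cccc(-c2nc(Nc3ccccc3)c3cc(F)ccc3n2)c1` gives 45500 nM. Compound 2 `Fc1cccc(-c2nc(Nc3ccccc3F)c3cc(F)ccc3n2)c1` reaches only the limit > 50000 nM in this assay. Compound 3 `Fc1cccc(-c2nc(Nc3ccccc3Cl)c3cc(F)ccc3n2)c1` likewise sits at the limit > 50000 nM in this assay. The steps of an at least 1.0-fold higher number from compound 1 to compound 2 (0.04 log units; that floor lies within the scatter) and an at least 1.0-fold higher number from compound 1 to compound 3 (0.04 log units; that floor lies within the scatter) both run into (the limit of > 50000 nM in this assay, at which 2 of the 3 values shown sit), and the step that the two limits leave unreadable from compound 2 to compound 3 cannot be read. Compound 4 `Oc1ccccc1Nc1nc(-c2cccc(F)c2)nc2ccc(F)cc12` differs from compound 2 by hydroxy in place of fluoro on an aromatic carbon. Among the measured compounds shown here, no measured step swaps one substituent for another with a readable size, so there is no parallel for hydroxy in place of fluoro. Compound 4 is therefore expected to stay near the limit, with a step of a number no higher from compound 2 to compound 4 (the limit leaves the size open) assumed as none beyond the scatter. Compound 4 is estimated at 50000 nM, ranging from 20000 nM to 150000 nM.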

Compound 4, half-maximal inhibitory concentration: 46300 nM
Compound 4: the middle estimate sits 1.1-fold (0.03 log units) above what was measured; the range from low to high includes it.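

Unlike fluoro and chloro, hydroxy ortho to a large group gives a readable value in this assay, and a 1.0-fold higher number from compound 1 to compound 4 (0.01 log units; within the scatter) shows no separation from hydrogen at this place. Against fluoro and chloro, only floors can be given, an at least 1.0-fold lower number from compound 2 to compound 4 (0.03 log units; that floor lies within the scatter) and an at least 1.0-fold lower number from compound 3 to compound 4 (0.03 log units; that floor lies within the scatter); both are small because each comparison ends at a limit: the limit of > 50000 nM in this assay, at which 2 of the 4 values shown sit.

Going by these compounds, whether an amine, a methoxy or a carboxylic acid at this place would move the number beyond the scatter stays open. On these data alone, how far the fluoro and chloro compounds truly lie from the hydroxy compound also stays open.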